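Swapping a Chlorothiophene for a Methylthiazole: Cytotoxicity Outlook

The compounds below may be only part of what the source reports. "The series", "measured", "known", "first", "only" and "open" are said of these compounds alone.

In an ADME assay on MDCK cells (Canis lupus familiaris) for cytotoxicity, read by microscopy, with a stated time of 48 h (on this read-out higher numbers stand for lower toxicity in this test and lower numbers for higher toxicity in this test), compound 3 `C[C@H]1[C@H](NCc2ccc(Cl)s2)C[C@H]2C[C@@H]1C2(C)C` gives 25000 nM. Compound 2 `C[C@H]1[C@H](NCc2ccc(Br)s2)C[C@H]2C[C@@H]1C2(C)C` gives 43000 nM, and the gap between them is a 1.7-fold lower number from compound 2 to compound 3 (0.24 log units; within the scatter). Compound 1 `C[C@H]1[C@H](NCc2cncs2)C[C@H]2C[C@@H]1C2(C)C` does not give a number but only a limit, > 100000 nM. Compound 4 `Cc1csc(CN[C@@H]2C[C@H]3C[C@@H]([C@H]2C)C3(C)C)n1` differs from compound 3 by 4-methyl-1,3-thiazol-2-yl in place of 5-chlorothiophen-2-yl on a saturated chain carbon bound to an amine nitrogen. Among the compounds with values here, the steps that bear on this are an at least 4.0-fold lower number from compound 1 to compound 3 (0.60 log units; beyond the scatter) and an at least 2.3-fold lower number from compound 1 to compound 2 (0.36 log units; beyond the scatter), both going from a thiazolyl group to a halothiophenyl group. The present change runs the opposite way, back to a thiazolyl group, so a rise in the number is expected, roughly matching the size of those steps. Compound 4 is therefore expected to give 70000 nM, within 30000 nM to 150000 nM. That expectation corresponds to a 2.8-fold higher number from compound 3 to compound 4 (0.45 log units; beyond the scatter).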

Compound 4, minimum cytotoxic concentration: > 100000 nM
Compound 4: a limit, no number; the forecaster's own chance of this, stated with the estimate: 35%; at least 1.4-fold (0.15 log units) between middle value and limit.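

Placing 4-methyl-1,3-thiazol-2-yl on this saturated chain carbon gives only a limit, not a number, yet the change can still be read as an at least 4.0-fold higher number from compound 3 to compound 4 (0.60 log units; beyond the scatter) and as an at least 2.3-fold higher number from compound 2 to compound 4 (0.36 log units; beyond the scatter). The earlier link between a thiazolyl group and the higher read-out thus rested on compound 1 alone; it now holds for a second, methyl-bearing thiazolyl group, and none of the four compounds goes against it. The step between the two thiazolyl compounds cannot be read because both give limits: the limit of > 100000 nM in this assay, at which 2 of the 4 values shown sit.

As far as these compounds go, how far either thiazolyl compound lies beyond its limit stays open. So does whether an unsubstituted thiophene or a pyridine ring would fall with the thiazolyl or the halothiophenyl compounds.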